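The source may hold more compounds than are shown below. What is called first, only, known or untested is meant among the compounds shown, and "the series" means these compounds.

Measured so far in a functional assay on SK-MEL-2 cells (Homo sapiens) for antiproliferative activity, read by sulforhodamine B assay, with a stated time of 48 h; on this read-out lower numbers stand for stronger inhibition and higher numbers for weaker inhibition: compound 1 `COc1cc(-c2nn(-c3ccc(NC(=O)Nc4ccc(Cl)c(C(F)(F)F)c4)cc3)cc2-c2ccncc2)ccc1Cl` gives 1630 nM; compound 2 `COc1cc(-c2nn(-c3ccc(NC(=O)Nc4cc(C(F)(F)F)cc(C(F)(F)F)c4)cc3)cc2-c2ccncc2)ccc1Cl` gives 1700 nM.

Compound 1 has the lower of the two numbers, but compound 2 lies within the usual scatter of it, so the two ureas cannot be told apart on this read-out. Compound 3 `COc1cc(-c2nn(-c3ccc(NC(=O)c4cc(Cl)cc(Cl)c4)cc3)cc2-c2ccncc2)ccc1Cl` has not been measured; it differs from compound 1 by 3,5-dichlorophenyl in place of (4-chloro-3-(trifluoromethyl)phenyl)amino on a carbonyl carbon. Among the measured compounds shown here, no measured pair shows a step of this kind, so there is no direct guide. A modest rise in the number is expected, a 2.1-fold higher number from compound 1 to compound 3 (0.33 log units; beyond the scatter), beyond the scatter but not large. Compound 3 is therefore estimated at 3500 nM, within a range from 1200 nM to 10000 nM.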

Compound 3, half-maximal inhibitory concentration: > 100000 nM
Compound 3: only a limit was reported; the forecaster's own chance of this, stated with the estimate: 10%; at least 28-fold (1.45 log units) between middle value and limit.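

Replacing (4-chloro-3-(trifluoromethyl)phenyl)amino with 3,5-dichlorophenyl on a carbonyl carbon shows that this position is far from indifferent, with an at least 61-fold higher number from compound 1 to compound 3 (1.78 log units; beyond the scatter). Compound 3 gives only a limit of the assay, not a number: the limit of > 100000 nM in this assay, at which 1 of the 3 values shown sits. The step removes the hydrogen-bond donor of the leaving group and changes the ring substituents at once, so it joins two changes in one.

The compounds shown leave open which of the two carries the loss. (3,5-Dichlorophenyl)amino on the same carbonyl carbon would separate them.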